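A few compounds are considered here, and "the series" means these few. Any claim that something is new, unique, unknown or untested is made for them only; others in the source may bear on it.

Measured so far in an in vitro assay on BL21-DE3 cells for displacement of a labelled ligand from thyroid hormone receptor beta (Homo sapiens), read by fluorescence polarization; on this read-out lower numbers stand for stronger inhibition and higher numbers for weaker inhibition:
- compound 1, `CCCCCCc1ccc(C(=O)CCN(CCCC)CCCC)cc1` — compound 1 gives 4200 nM
- compound 2, `CCCCCCc1ccc(C(=O)/C=C\C(=O)O)cc1` — compound 2 gives 17700 nM
- compound 3, `C/C=C/C(=O)c1ccc(CCCCCCC)cc1` — compound 3 gives 7600 nM

All three share a benzene ring carrying a long alkyl chain on one side and a carbonyl group on the other; they differ only in what hangs off that carbonyl. Among the three numbers, compound 3 stands second highest. Its nearest neighbour is compound 1, whose number lies within the usual scatter of compound 3, so the two cannot be told apart. Its furthest neighbour is compound 2, whose number lies beyond the scatter, higher than that of compound 3.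

Compound 4, `C=CC(=O)c1ccc(CCCCCCC)cc1`, has not yet been measured in this assay. It is obtained from compound 3 by a single change: vinyl in place of prop-1-en-1-yl on a carbonyl carbon. Going by the values given here, no pair of measured compounds shows this same change, so its effect can only be guessed. The compounds in hand all bind weakly, and a change this small is expected to move the number little. The step of a 1.2-fold higher number from compound 3 to compound 4 (0.07 log units; within the scatter) is estimated to stay close to the scatter. Compound 4 is therefore expected to give about 9000 nM, plausibly between 3500 nM and 23000 nM.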

Compound 4, half-maximal inhibitory concentration: 10500 nM
Compound 4: the middle estimate sits 1.2-fold (0.07 log units) below what was measured; the range from low to high includes it.
By their numbers in this assay, from the lowest: compounds 1, 3, 4 and 2 (each within the scatter of the next, the first and the last beyond it).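

In this assay, vinyl in place of prop-1-en-1-yl on a carbonyl carbon gives a 1.4-fold higher number from compound 3 to compound 4 (0.14 log units; within the scatter) and so leaves compound 3 and compound 4 indistinguishable. Going by these compounds alone, this is the first direct reading at this position, and it shows that exchanging one of these two small hydrocarbon groups for the other, each with a double bond outside the aromatic ring, makes no measurable difference here. No separate measurement bears on the reason for this result.

As far as these compounds go, whether the double bond itself matters remains open, as neither compound 3 nor compound 4 has a counterpart with an ethyl group on the carbonyl carbon. From the compounds shown here alone, how far this position tolerates larger groups also remains open, as a phenyl group there would be needed to test it.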